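Compound 2 to compound 3: loss of the methyl

The compounds below may be only part of what the source reports. "The series", "measured", "known", "first", "only" and "open" are said of these compounds alone.

In an ADME assay on MT4 cells (Homo sapiens) for cytotoxicity, read by MTT assay, with a stated time of 96 h (a higher number here means that more compound is tolerated, a lower number that less compound is tolerated), compound 2 `Cc1ccc(NCc2cn(-c3ccccc3)nc2-c2ccc(C)cc2)cc1` gives > 100000 nM as a limit of the assay and not a number. Compound 1 `Cc1ccc(NCc2cn(-c3ccccc3)nc2-c2ccc(Cl)cc2)cc1` gives > 100000 nM as a limit too. No value for compound 2 can therefore serve as a fixed starting point.

The next change leads to compound 3 `Cc1ccc(NCc2cn(-c3ccccc3)nc2-c2ccccc2)cc1` and puts hydrogen in place of methyl on an aromatic carbon, para to a large group, so that 4-methylphenyl becomes phenyl (hydrogen in place of methyl on an aromatic carbon).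

Going by the values given here, one measured step bears on this change: a step that the two limits leave unreadable from compound 1 to compound 2, with methyl in place of chloro on an aromatic carbon. It gives no size to carry over. Among the compounds with values here, the two compounds share (the limit of > 100000 nM in this assay, at which 2 of the 2 values shown sit), and no compound yet gives a number in this assay. With so little to go on, no step beyond the scatter is expected in either direction.

The expected step is a number no higher from compound 2 to compound 3 (the limit leaves the size open), and it may again be unreadable. For compound 3 the estimate is 100000 nM, with an expected range of 50000 nM to 200000 nM, and another limit is the likeliest report.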

Compound 3, half-maximal cytotoxic concentration: > 100000 nM
Compound 3: only a limit was reported (the forecaster's own chance of this, stated with the estimate: 85%); the middle value lies on the limit itself.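

No step can be read among compound 1, compound 2 and compound 3 in this assay, as all three values are limits of the assay and not numbers: the limit of > 100000 nM in this assay, at which 3 of the 3 values shown sit.

The compounds shown leave open where the half-maximal cytotoxic concentration of each lies, and whether chloro, methyl or hydrogen on this aromatic carbon makes any difference to it.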